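A few compounds are considered here, and "the series" means these few. Any claim that something is new, unique, unknown or untested is made for them only; others in the source may bear on it.

The measured compounds are:

Compound 1, `N#CN/C(=N\CCNc1ccc(N=[N+]=[N-])cc1[N+](=O)[O-])NCCCOc1cccc(CN2CCCCC2)c1`: 7.39
Compound 2, `N#CN/C(=N\CCCCNC(=O)c1ccccc1)NCCCOc1cccc(CN2CCCCC2)c1`: 6.81
Compound 3, `N#CN/C(=N\CCCCCNC(=O)c1ccccc1)NCCCOc1cccc(CN2CCCCC2)c1`: 6.58

In a functional assay on cardiac atrium for antagonist activity at histamine H2 receptor (Cavia porcellus) (a lower number here means a less potent compound, a higher number a more potent compound, by a factor of ten per unit of this negative logarithm), compound 3 stands lowest of the three measured numbers. Its nearest neighbour is compound 2, whose value lies higher by a number 0.23 log units lower from compound 2 to compound 3 (within the scatter), a step within the scatter. The furthest is compound 1, whose value stands well above that of compound 3, beyond the scatter.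

Compound 4, `N#CN/C(=N\CCNC(=O)CCc1ccccc1)NCCCOc1cccc(CN2CCCCC2)c1`, has not yet been measured. It differs from compound 3 by (phenethylcarbonyl)amino in place of 3-benzamidopropyl on a saturated chain carbon, two bonds along the chain from a double-bonded nitrogen. Going by the values given here, the only measured step that touches this series is the one from compound 2 to compound 3, a lengthening of the chain that gave a number 0.23 log units lower from compound 2 to compound 3 (within the scatter); it bears on the chain change here only loosely, and no step with a shifted phenyl group has been measured. On that basis the step from compound 3 to compound 4 in this assay is expected to be small, a number 0.22 log units higher from compound 3 to compound 4 (within the scatter), with direction uncertain. Compound 4 is therefore estimated at 6.8, in the range 6.2 to 7.4.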

Compound 4, negative logarithm of the antagonist equilibrium constant: 6.27
Compound 4: middle estimate off by 0.53 log units, on the high side; low and high end bracket the measured number.
By their numbers in this assay, from the lowest: compound 4; then compounds 3 and 2 (each within the scatter of the next); then compound 1.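

In this assay, (phenethylcarbonyl)amino on the saturated chain carbon, two bonds along the chain from a double-bonded nitrogen, gives the first change among these amides that lies beyond the scatter: a number 0.31 log units lower from compound 3 to compound 4 (beyond the scatter), and a number 0.54 log units lower from compound 2 to compound 4 (beyond the scatter), whereas the earlier chain step, a number 0.23 log units lower from compound 2 to compound 3 (within the scatter), stayed within it. The largest of the new steps, a number 1.12 log units lower from compound 1 to compound 4 (beyond the scatter), comes with phenethylcarbonyl in place of 4-azido-2-nitrophenyl on an amine nitrogen, so the group on that nitrogen counts for more here than either amide step. Nothing available accounts for these drops.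

On these data alone, the two amide steps change the chain and the amide together, so their separate shares stay open. Also open, as far as these compounds go, is whether a longer chain before the (phenethylcarbonyl)amino group, or a nitro or azide on its phenyl ring, would bring the number closer to that of compound 1.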